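Replacing 4-bromophenyl in a cytotoxicity pair

The compounds below may be only part of what the source reports. "The series", "measured", "known", "first", "only" and "open" are said of these compounds alone.

In a functional assay on HeLa cells (Homo sapiens) for cytotoxicity, read by MTT assay, with a stated time of 24 h (on this read-out higher numbers stand for weaker inhibition and lower numbers for stronger inhibition), compound 1 (`CN1C/C(=C\c2ccc(C#N)cc2)C(=O)/C(=C/c2ccccc2F)C1`) gives 1340 nM, while compound 2 (`CN1C/C(=C\c2ccc(Br)cc2)C(=O)/C(=C/c2ccc(C#N)cc2)C1`) gives 5900 nM, the higher and thus weaker of the two numbers. Compound 3 (`CN1C/C(=C\c2ccc(C#N)cc2)C(=O)/C(=C/c2ccc(Cl)cc2Cl)C1`) differs from compound 2 on a double-bonded chain carbon bound to a double-bonded ring carbon: 2,4-dichlorophenyl in place of 4-bromophenyl on a double-bonded chain carbon bound to a double-bonded ring carbon. Going by the values given here, only one measured step bears on this: a 4.4-fold higher number from compound 1 to compound 2 (0.64 log units; beyond the scatter), a modest change that brought in 4-bromophenyl. Compound 1 at 1340 nM also lacks that group, so a lower number is expected in this assay, though a single step is thin evidence. The expected change is a 2.4-fold lower number from compound 2 to compound 3 (0.37 log units; beyond the scatter). The estimate for compound 3 is 2500 nM, with an expected range of 900 nM to 6500 nM.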

Compound 3, half-maximal inhibitory concentration: 7760 nM
Compound 3: the middle estimate sits 3.1-fold (0.49 log units) below what was measured; measured number outside the range, above it.
By their numbers in this assay, from the lowest: compound 1; then compounds 2 and 3 (each within the scatter of the next).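

In this assay, 2,4-dichlorophenyl in place of 4-bromophenyl at this position makes no clear difference (a 1.3-fold higher number from compound 2 to compound 3 (0.12 log units; within the scatter)), so these two groups cannot be told apart here. The step from the 2-fluorophenyl of compound 1 is clearer (a 5.8-fold higher number from compound 1 to compound 3 (0.76 log units; beyond the scatter)), and compound 1 now has the lowest number, with steps beyond the scatter to both other compounds. No measurement shown explains this gap. Still open, going by these compounds, is how an unsubstituted phenyl, or a phenyl carrying an amine or a carboxylic acid, would behave at this position.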